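From Fluoro to an Amide Chain on Compound 2

The source may hold more compounds than are shown below. What is called first, only, known or untested is meant among the compounds shown, and "the series" means these compounds.

In an assay on cell membranes for displacement of a labelled ligand from Adrenergic receptor alpha-1 (Rattus norvegicus), tested at 100 nM (a lower number here means a stronger inhibitor, a higher number a weaker inhibitor), two compounds have been measured:
Compound 1 `C/C=C/C=C/C(=O)N1CCN(c2nc(N)c3cc(OC)c(OC)cc3n2)CC1` gives 4.37 nM.
Compound 2 `COc1cc2nc(N3CCN(C(=O)/C=C/c4ccc(F)cc4)CC3)nc(N)c2cc1OC` gives 22.9 nM.

Compound 2 stands highest of these two numbers; its nearest neighbour is compound 1, separated by the step of a 5.2-fold higher number from compound 1 to compound 2 (0.72 log units; beyond the scatter). Compound 3 `COC(=O)/C=C/C(=O)Nc1ccc(/C=C/C(=O)N2CCN(c3nc(N)c4cc(OC)c(OC)cc4n3)CC2)cc1` is not yet measured. It differs from compound 2 by ((2-(methoxycarbonyl)ethenyl)carbonyl)amino in place of fluoro on an aromatic carbon. Among the measured compounds shown here, the one measured step, a 5.2-fold higher number from compound 1 to compound 2 (0.72 log units; beyond the scatter), concerns a different place, the double-bonded chain carbon, and is modest in size, so it bears only loosely on the present change. For the measured compounds named here, with no measured step at the aromatic carbon itself, the expectation rests on the size of the added group and on the weak position of compound 2. A small weakening is expected, as a 1.4-fold higher number from compound 2 to compound 3 (0.15 log units; within the scatter). Compound 3 is therefore estimated at 32 nM in this assay, within a range from 8 nM to 130 nM.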

Compound 3, half-maximal inhibitory concentration: 29.5 nM
The estimate for compound 3 lay 1.1-fold (0.04 log units) above the measured number; the range from low to high includes it.
By their numbers in this assay, from the lowest: compound 1; then compounds 2 and 3 (each within the scatter of the next).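

At the aromatic carbon para to a large group, the small fluoro gives way to the far larger ((2-(methoxycarbonyl)ethenyl)carbonyl)amino with a 1.3-fold higher number from compound 2 to compound 3 (0.11 log units; within the scatter) in this assay and so leaves the number within the scatter. Among the compounds shown here, this pair therefore shows what the earlier compounds could not: this position accepts a chain that brings a hydrogen-bond donor, hydrogen-bond acceptors and double bonds outside aromatic rings without a measurable shift in this assay. No available evidence explains this outcome.

The compounds shown leave open which part of the chain, if any, matters, as a carboxylic acid in place of the methyl ester could behave differently. They also leave open whether a plain amine or a longer chain on the same aromatic carbon would stay within the scatter of compound 2.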